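This account rests on a few compounds, and the source may have more. Where it says the series, first, only, none or still open, it means among the compounds named here.

Measured compounds:

compound 1 `O=C(Nc1ccccc1Cl)c1cc(Cl)ccc1O`: in a physicochemical assay for solubility (a lower number here means a less soluble compound, a higher number a more soluble compound), compound 1 gives 5 ug/mL
compound 2 `O=C(Nc1ccc(Cl)cc1Cl)c1cc(Cl)ccc1O`: compound 2 gives a limit of the assay, < 1 ug/mL
compound 3 `O=C(Nc1ccc(C(F)(F)F)cc1)c1cc(Br)ccc1O`: compound 3 also gives a limit of the assay, < 1 ug/mL

Compound 1 and compound 2 share a core and differ by the change (chloro in place of hydrogen on an aromatic carbon). That change made a step of an at least 5.0-fold lower number from compound 1 to compound 2 (0.69 log units; beyond the scatter), an at least modest fall in solubility, with the end of the step resting on the point (the limit of < 1 ug/mL in this assay, at which 2 of the 3 values shown sit), so that the full size of the fall is not known.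

Compound 3 carries a different core; the difference between the core of compound 1 and the core of compound 3 is not broken down here. The compound yet to be measured is compound 4 `O=C(Nc1ccc(C(F)(F)F)cc1Cl)c1cc(Br)ccc1O`, which differs from compound 3 by the change (chloro in place of hydrogen on an aromatic carbon). For the measured compounds named here, this is the same kind of change as the one from compound 1 to compound 2, though the surroundings differ: in compound 4 the chloro enters ortho to a large group and meta to a trifluoromethyl group, while in compound 2 it entered meta to a chloro group and para to a large group.

In this assay, compound 3 already sits at a limit. Since the earlier chloro step lowered the number, compound 4 is expected to remain at or under that limit, an expected step that the limit leaves unreadable from compound 3 to compound 4. The solubility of compound 4 is therefore estimated at 0.3 ug/mL, within 0.05 ug/mL to 1.5 ug/mL, and most likely reported only as a limit.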

Compound 4, solubility: < 1 ug/mL
Compound 4 gave a limit, no number; the forecaster's own chance of this, stated with the estimate: 90%; the middle value lies beyond the limit too.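

In this assay, compound 3 and compound 4 both give a limit of the assay and not a number, so no step can be read between them, because neither value has a measurable size: the limit of < 1 ug/mL in this assay, at which 3 of the 4 values shown sit.

The compounds shown leave open whether chloro in place of hydrogen changes the solubility of compound 3 at all, and how compound 2, compound 3 and compound 4 rank among themselves.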